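From phenylethynyl to but-1-yn-1-yl on the shared core

The source may report more compounds than this note shows. Statements on the series, on what has been measured and on what is new or still open speak of the compounds shown alone.

Values in an ADME assay on L1210/0 cells (Mus musculus) for cytotoxicity, with a stated time of 48 h (on this read-out lower numbers stand for stronger inhibition and higher numbers for weaker inhibition), so far
Compound 1 `N#CSc1cn([C@H]2C[C@H](O)[C@@H](CO)O2)c(=O)[nH]c1=O` gives 78900 nM
Compound 2 `O=c1[nH]c(=O)n([C@H]2C[C@H](O)[C@@H](CO)O2)cc1C#Cc1ccccc1` gives > 200000 nM as a limit

Compound 2 gives > 200000 nM as a limit and not a number, and so stands at the limit of > 200000 nM in this assay, at which 1 of the 2 values shown sits, with no finer placing. Compound 3 `CCC#Cc1cn([C@H]2C[C@H](O)[C@@H](CO)O2)c(=O)[nH]c1=O` differs from compound 2 by ethyl in place of phenyl on a triple-bonded carbon and carries ethyl in place of phenyl on a triple-bonded carbon. Going by the values given here, the one measured step that bears on this, at another substitution, is (an at least 2.5-fold higher number from compound 1 to compound 2 (0.40 log units; beyond the scatter)) and gives only a loose guide. Among the compounds with values here, a modest step to a lower number is therefore expected in this assay with compound 1 at 78900 nM as the only true number for reference. For compound 3 the expected step is (an at least 1.8-fold lower number from compound 2 to compound 3 (0.25 log units; that floor lies within the scatter)) in size. The estimated value for compound 3 is 110000 nM (range 35000 nM to 200000 nM).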

Compound 3, half-maximal inhibitory concentration: > 200000 nM
Compound 3: only a limit was reported; the forecaster's own chance of this, stated with the estimate: 40%; at least 1.8-fold (0.25 log units) between middle value and limit.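

In this assay compound 3 gives > 200000 nM, which is a limit and not a number. Putting but-1-yn-1-yl in place of cyanosulfanyl on an aromatic carbon gives an at least 2.5-fold higher number from compound 1 to compound 3 (0.40 log units; beyond the scatter), so the higher number does not depend on a terminal phenyl, as ethyl in that place also gives it. The step from phenyl to ethyl on a triple-bonded carbon cannot be read: the limit of > 200000 nM in this assay, at which 2 of the 3 values shown sit.

Any order between these two groups stays open. So does whether a hydroxymethyl or an amine at the end of the triple bond would give a true number in this assay.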